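The compounds below may be only part of what the source reports. "The series", "measured", "known", "first", "only" and "open" are said of these compounds alone.

Among the compounds with values here, compound 1 `Cc1cc(Nc2cc(N3CCN(C)CC3)nc(Nc3ccc(S(N)(=O)=O)cc3)n2)n[nH]1` gives 16700 nM in a functional assay on A549 cells (Homo sapiens) for antiproliferative activity, read by CCK-8 assay, with a stated time of 72 h (a lower number here means a stronger inhibitor, a higher number a weaker inhibitor), and compound 2 `COc1cccc(Nc2nc(Nc3cc(C)[nH]n3)cc(N3CCN(C)CC3)n2)c1` gives 1690 nM there, the lower of the only two numbers so far. Compound 3 `Cc1cc(Nc2cc(N3CCN(C)CC3)nc(Nc3cccc([N+](=O)[O-])c3)n2)n[nH]1` keeps the shared core and carries nitro in place of methoxy on an aromatic carbon, meta to a large group, and the change counts as nitro in place of methoxy on an aromatic carbon with nothing else altered. Within the data shown here, only one measured step bears on this. It is a 9.9-fold lower number from compound 1 to compound 2 (0.99 log units; beyond the scatter) and lies beyond the scatter, with 3-methoxyphenyl in place of 4-sulfamoylphenyl on a nitrogen on an aromatic ring. That modest step shows that a change in this part of the structure can move the number, but it does not test nitro. Compound 2 at 1690 nM holds the lower mark of the pair, so a small rise is expected in this assay rather than a further fall, and it should be smaller than that step. Compound 3 is expected at 4000 nM with an estimated range from 1200 nM to 13000 nM as its bounds. This estimate means a 2.4-fold higher number from compound 2 to compound 3 (0.37 log units; beyond the scatter) as the expected change.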

Compound 3, half-maximal inhibitory concentration: 926 nM
Estimate against measurement, compound 3: 4.3-fold (0.64 log units) above; the measured number lies below the stated range.
By their numbers in this assay, from the lowest: compounds 3 and 2 (each within the scatter of the next); then compound 1.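

In this assay the change from methoxy to nitro gives a 1.8-fold lower number from compound 2 to compound 3 (0.26 log units; within the scatter), so on this aromatic carbon, meta to a large group, the two groups cannot be told apart by this read-out, something the earlier step could not show because it altered the whole substituent on the nitrogen. The change of 3-nitrophenyl for 4-sulfamoylphenyl gives an 18-fold lower number from compound 1 to compound 3 (1.26 log units; beyond the scatter) and lies beyond the scatter, so two different groups at this place now both stand clear of compound 1 in the same direction. No measurement shown here offers a reason for these numbers.

On these data alone, it remains open whether an amine, a carboxylic acid or a plain hydrogen at this same place would also stay within the scatter of compound 2 and compound 3. Also open is whether the higher number of compound 1 belongs to the sulfamoyl group itself or to where it sits on the ring, as the compounds shown change both at once.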